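The source may hold more compounds than are shown below. What is called first, only, known or untested is meant among the compounds shown, and "the series" means these compounds.

Three compounds share one core and differ only in the group hung from the ether oxygen. Compound 1 `Cc1cc(COc2ccccc2Cl)nc(-c2ccccn2)n1` carries a 2-chlorophenyl and, in a functional assay on cells for antagonist activity at Free fatty acid receptor 1 (Homo sapiens), read by TR-FRET and inositol phosphate accumulation, with a stated time of 2 h (on this read-out lower numbers stand for stronger inhibition and higher numbers for weaker inhibition), compound 1 gives 316 nM. Compound 2 `COc1ccc(OCc2cc(C)nc(-c3ccccn3)n2)cc1` has the methoxy moved to the far side of the ring, and in this assay compound 2 gives 7940 nM, a number that is far higher than that of compound 1 and beyond the usual scatter. Compound 3 `Cc1cc(COc2cccc(S(C)(=O)=O)c2)nc(-c2ccccn2)n1` carries a methylsulfonyl group, and for compound 3 this assay reports only a limit, > 39800 nM, not a number; one of the three values shown sits at this limit (the limit of > 39800 nM in this assay, at which 1 of the 3 values shown sits). Among the two actual numbers, compound 1 therefore stands lowest.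

Compound 4 `Cc1cc(COc2ccccc2F)nc(-c2ccccn2)n1` keeps everything of compound 1 except that (fluoro in place of chloro on an aromatic carbon). Going by the values given here, no pair of measured compounds shows this exact swap, so its effect here is unknown. The halogen stays on the same aromatic carbon, and the change is small in size. The expected step of a 2.0-fold higher number from compound 1 to compound 4 (0.30 log units; within the scatter) is modest, toward a somewhat higher number, close to the scatter. Compound 4 is estimated at 630 nM, with a plausible range from 200 nM to 2500 nM.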

Compound 4, half-maximal inhibitory concentration: 398 nM
Compound 4: middle estimate off by 1.6-fold (0.20 log units), on the high side; low and high end bracket the measured number.
By their numbers in this assay, from the lowest: compounds 1 and 4 (each within the scatter of the next); then compound 2. At a limit, above all of these: compound 3.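

Putting fluoro in place of chloro on this aromatic carbon, ortho to a large group, gives in this assay a 1.3-fold higher number from compound 1 to compound 4 (0.10 log units; within the scatter), so the two compounds cannot be told apart. Going by these compounds alone, this is the first step that changes one atom and nothing else, and it shows that at this place, chloro and fluoro serve equally well on this read-out.

Whether the halogen is needed at all remains open, since a plain phenyl with only hydrogen at this place is not among the compounds shown. Also open, on these data alone, is how methyl, methoxy or an amine would fare on this same carbon, and whether a bromo would stay level with chloro and fluoro. Nothing measured here bears on why the two halogens give such similar numbers.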